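Neopentyl to isopropyl on the ring nitrogen of compound 3

This account rests on a few compounds, and the source may have more. Where it says the series, first, only, none or still open, it means among the compounds named here.

Measured in an assay on CHO cells for displacement of a labelled ligand from adenosine receptor A3 (Homo sapiens), read by scintillation counting, with a stated time of 3 h; a lower number here means a stronger inhibitor, a higher number a weaker inhibitor:
compound 1 `Cc1ccc(C(=O)Nc2nc(Cl)c3cn(C)nc3n2)cc1` gives 13500 nM
compound 2 `CCOC(=O)c1nc(NC(=O)c2ccc(C)cc2)nc2nn(CC(C)(C)C)cc12` gives 900 nM
compound 3 `CC(C)(C)Cn1cc2c(Cl)nc(NC(=O)c3ccccc3)nc2n1` gives 30300 nM

Compound 3 stands at the highest number of the three and is the weakest inhibitor; the nearest value is that of compound 1, the furthest that of compound 2, both gaps beyond the scatter. Compound 4 `CC(C)n1cc2c(Cl)nc(NC(=O)c3ccccc3)nc2n1` is not yet measured. It differs from compound 3 in one place: isopropyl in place of neopentyl on an aromatic nitrogen. Among the compounds with values here, no measured pair shows this change on its own, so the size of its step in this assay is unknown; a small step, not clearly beyond the scatter, is expected, with a slight lean toward a lower number given that compound 1 with its smaller group gives 13500 nM. Compound 4 is therefore estimated at 20000 nM, within 6000 nM to 60000 nM, a step of a 1.5-fold lower number from compound 3 to compound 4 (0.18 log units; within the scatter).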

Compound 4, inhibition constant: 12800 nM
Beside the measured number, compound 4's estimate is 1.6-fold (0.19 log units) above it, and the stated range covers the measured number.
By their numbers in this assay, from the lowest: compound 2; then compounds 4 and 1 (each within the scatter of the next); then compound 3.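

In this assay, within the data shown here, isopropyl in place of neopentyl on the aromatic nitrogen gives a 2.4-fold lower number from compound 3 to compound 4 (0.37 log units; beyond the scatter), the first reading of this position with the rest of the structure held constant. The substituent here is therefore not silent: the change from neopentyl to isopropyl moves the number modestly, and in the direction of stronger inhibition. Nothing available explains this step.

A single pair gives no trend across substituent size at this nitrogen. As far as these compounds go, whether a cyclopentyl ring, or a longer chain ending in an amine, would extend or reverse the step remains open.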